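This account rests on a few compounds, and the source may have more. Where it says the series, first, only, none or still open, it means among the compounds named here.

Compound 1 `CC(C)c1n[nH]c2c(NCc3ccc(-c4ccccn4)cc3)nc(SCCN)nc12` is the strongest of the three measured compounds: in a functional assay on HT cells (Homo sapiens) for antiproliferative activity, read by fluorescence, with a stated time of 72 h (on this read-out lower numbers stand for stronger inhibition of growth and higher numbers for weaker inhibition of growth), compound 1 gives 22 nM, the lowest number of the set. Its nearest neighbour is compound 2 `CC(C)c1n[nH]c2c(NCc3ccc(-c4ccccn4)cc3)nc(SCC(N)=O)nc12`, which in this assay gives 192 nM; the step of an 8.7-fold higher number from compound 1 to compound 2 (0.94 log units; beyond the scatter) corresponds to carbamoyl in place of aminomethyl on a saturated chain carbon bound to a sulfur. Further off is compound 3 `COCSc1nc(NCc2ccc(-c3ccccn3)cc2)c2[nH]nc(C(C)C)c2n1`, which gives 340 nM; the step of a 15-fold higher number from compound 1 to compound 3 (1.19 log units; beyond the scatter) corresponds to methoxy in place of aminomethyl on a saturated chain carbon bound to a sulfur. Between compound 2 and compound 3 the step of a 1.8-fold higher number from compound 2 to compound 3 (0.25 log units; within the scatter) is too small to count.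

Compound 4 `CC(=O)NCCSc1nc(NCc2ccc(-c3ccccn3)cc2)c2[nH]nc(C(C)C)c2n1` is made from compound 1 by acetyl in place of hydrogen on an amine nitrogen. The chain stays, but the amine nitrogen now carries an acetyl, so compound 4 holds an amide group, much as compound 2 does. Both measured steps away from compound 1 altered the amine end of the chain and both weakened inhibition in this assay; the carbamoyl step to compound 2 is the closer comparison. A step of similar size in the same direction, toward weaker inhibition of growth, is therefore expected for compound 4. Compound 4 is estimated to give 150 nM in this assay, with a range of 50 nM to 500 nM, which would be a step of a 6.8-fold higher number from compound 1 to compound 4 (0.83 log units; beyond the scatter).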

Compound 4, concentration for 50% growth inhibition: 71 nM
For compound 4 the middle estimate is 2.1-fold (0.32 log units) above the measured one; measured number inside the range.
By their numbers in this assay, from the lowest: compound 1; then compound 4; then compounds 2 and 3 (each within the scatter of the next).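

In this assay, acetyl on the amine nitrogen weakens inhibition of growth, with a 3.2-fold higher number from compound 1 to compound 4 (0.51 log units; beyond the scatter), so the free amine of compound 1 keeps the lowest number of the four, although the acetylated chain still holds much of that strength. Compound 2 and compound 3 could not be told apart, but the new chain separates from both, with a 2.7-fold lower number from compound 2 to compound 4 (0.43 log units; beyond the scatter) and with a 4.8-fold lower number from compound 3 to compound 4 (0.68 log units; beyond the scatter), so a 2-acetamidoethyl chain on the sulfur gives stronger inhibition of growth than either earlier replacement for the 2-aminoethyl chain. Compound 2 and compound 4 both hold an amide group and still differ beyond the scatter, which shows that the presence of an amide alone does not fix the number at this position, and nothing in the data explains why these values differ.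

Still open, on these data alone, is whether a longer chain ending in an amine, a dimethylamino group or a carboxylic acid in place of the amine would match or beat compound 1. With a single cell line, these compounds also leave open whether the same order would hold in other cells.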